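This account rests on a few compounds, and the source may have more. Where it says the series, first, only, none or still open, it means among the compounds named here.

Compound 1 `COc1ccc2nc(C)cc(NCc3ccccc3)c2c1`: 25900 nM
Compound 2 `COc1ccc2nc(C)cc(NCC3CCCN(C)C3)c2c1`: 6400 nM

Among the measured compounds shown here, in a functional assay on MCF-10A cells (Homo sapiens) for antiproliferative activity, with a stated time of 48 h (on this read-out lower numbers stand for an effect already at smaller amounts and higher numbers for an effect only at larger amounts of compound), compound 1 stands highest of the two measured compounds, and compound 2 is the only neighbour. Compound 3 `COc1ccc2nc(C)cc(NCc3ccc(N(C)C)cc3)c2c1` carries dimethylamino in place of hydrogen on an aromatic carbon of compound 1: dimethylamino in place of hydrogen on an aromatic carbon. For the measured compounds named here, only one measured step bears on this, and only indirectly, since it makes a different change on the same side chain: a 4.0-fold lower number from compound 1 to compound 2 (0.61 log units; beyond the scatter). On that modest evidence, a similar or smaller drop is expected. The estimated change is a 2.4-fold lower number from compound 1 to compound 3 (0.37 log units; beyond the scatter). For compound 3, the expected value is 11000 nM, with an estimated range of 4500 nM to 26000 nM.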

Compound 3, half-maximal effective concentration: 15100 nM
Compound 3: middle estimate off by 1.4-fold (0.14 log units), on the low side; measured number inside the range.
By their numbers in this assay, from the lowest: compound 2; then compounds 3 and 1 (each within the scatter of the next).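

In this assay, dimethylamino on the aromatic carbon para to a large group gives a 1.7-fold lower number from compound 1 to compound 3 (0.23 log units; within the scatter), so this change to the ring of compound 1 has no effect that can be told from the scatter. Among the compounds shown here, it is the first reading at this position, as the earlier step changed the ring as a whole rather than a substituent on it. Nothing measured here offers an explanation for this result. Going by these compounds, it remains open whether a smaller amine, a carboxylic acid or a methoxy group at this carbon would give a clearer shift.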